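This account rests on a few compounds, and the source may have more. Where it says the series, first, only, none or still open, it means among the compounds named here.

Measured so far in a functional assay on PC-3 cells (Homo sapiens) for antiproliferative activity, read by MTT assay, with a stated time of 48 h; on this read-out higher numbers stand for weaker inhibition of growth and lower numbers for stronger inhibition of growth:
- compound 1 `CCN(Cc1ccc(C(=O)NO)cc1)c1ncc(-c2ccc(C)cc2)s1`: 10300 nM
- compound 2 `CCCCCCCCN(Cc1ccc(C(=O)NO)cc1)c1ncc(-c2ccc(C)cc2)s1`: 13300 nM
- compound 3 `Cc1ccc(OCCCCN(Cc2ccc(C(=O)NO)cc2)c2ncc(-c3ccc(C)cc3)s2)cc1`: 1220 nM

Compound 1 stands second highest of the three numbers shown. Its nearest neighbour is compound 2, with a 1.3-fold higher number from compound 1 to compound 2 (0.11 log units; within the scatter); its furthest is compound 3, with an 8.4-fold lower number from compound 1 to compound 3 (0.93 log units; beyond the scatter). Between compound 2 and compound 3 the step is an 11-fold lower number from compound 2 to compound 3 (1.04 log units; beyond the scatter).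

Compound 4 `CCCCCCN(Cc1ccc(C(=O)NO)cc1)c1ncc(-c2ccc(C)cc2)s1` has not yet been measured. Relative to compound 1 the change is butyl in place of hydrogen on a saturated chain carbon, two bonds along the chain from a nitrogen on an aromatic ring. Among the measured compounds shown here, the step that bears on it most directly is the one from compound 1 to compound 2, where a longer chain enters at the same place: a 1.3-fold higher number from compound 1 to compound 2 (0.11 log units; within the scatter), within the scatter. For the measured compounds named here, the only step beyond the scatter in the set, from compound 1 to compound 3, brings in a ring-bearing group and so does not speak to a plain chain. On this basis no step beyond the scatter is expected in this assay for compound 4, in either direction. The estimate for compound 4 is therefore 11000 nM, with a range from 5000 nM to 25000 nM, which would mean an expected step of a 1.1-fold higher number from compound 1 to compound 4 (0.03 log units; within the scatter).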

Compound 4, concentration for 50% growth inhibition: 5270 nM
Compound 4: the middle estimate sits 2.1-fold (0.32 log units) above what was measured, within the range that was stated.
By their numbers in this assay, from the lowest: compound 3; then compounds 4, 1 and 2 (each within the scatter of the next, the first and the last beyond it).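

In this assay, plain chains at this position, on a saturated chain carbon two bonds along the chain from a nitrogen on an aromatic ring, no longer read as a single level: the butyl change gives a 2.0-fold lower number from compound 1 to compound 4 (0.29 log units; within the scatter) and stays within the scatter, but removing ethyl further out gives a 2.5-fold lower number from compound 2 to compound 4 (0.40 log units; beyond the scatter) and separates two plain chains by more than the scatter. Even so, the chain with a ring at its end stays apart from the closest plain chain, since ethyl in place of 4-methylphenoxy gives a 4.3-fold higher number from compound 3 to compound 4 (0.64 log units; beyond the scatter) and none of compounds 1, 2 and 4 reaches the number of compound 3 at 1220 nM. Nothing measured here accounts for these differences.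

With only three plain chains, the values do not settle whether the response to chain length has a true turning point, and a butyl or octyl chain ending in the same 4-methylphenoxy group would test how much the chain length matters when the ring is present. Also open, going by these compounds, is whether the gain in compound 3 needs the ether oxygen, the phenyl ring or both, which a plain phenyl ending, an unsubstituted phenoxy, a terminal amine or a carboxylic acid on the chain would begin to separate.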